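The source may report more compounds than this note shows. Statements on the series, on what has been measured and on what is new or still open speak of the compounds shown alone.

Measured compounds:
compound 1 `O=C1Nc2ccc(F)cc2/C1=N/NC(=S)Nc1ccccc1C(F)(F)F`: 25%
compound 2 `O=C1Nc2ccc(F)cc2/C1=N/NC(=S)Nc1ccc(C(F)(F)F)cc1`: 25%
compound 3 `O=C1Nc2ccc(F)cc2/C1=N/NC(=S)Nc1ccccc1F`: 35%

All three were tested in a functional assay on the whole organism for inhibition, with Lemna aequinoctialis as the target, with a stated time of 7 days, tested at 500 ug/mL; a lower number here means less inhibition of growth, a higher number more inhibition of growth at the concentration tested. Compound 3 gives 35%, which lies within the usual scatter of the numbers for compound 1 and compound 2, so the three cannot be told apart.

Still unmeasured is compound 4 `O=C1Nc2ccc(F)cc2/C1=N/NC(=S)Nc1c(F)cccc1F`. It turns the 2-fluorophenyl of compound 3 into 2,6-difluorophenyl, with fluoro in place of hydrogen on an aromatic carbon.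

Among the compounds with values here, only one measured step bears on this, the exchange of trifluoromethyl for fluoro, a number 10 percentage points higher from compound 1 to compound 3 (within the scatter). Within the data shown here, it is a different exchange, and no measured pair shows a second fluoro being added, so the evidence is indirect. Still, this one step stayed small, and so no shift beyond the scatter is expected. The expected step is no change at the digits printed from compound 3 to compound 4 (within the scatter).

For compound 4 the estimated value is 35%, with an expected range from 20% to 50%.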

Compound 4, percent growth inhibition at one concentration: 30%
Estimate against measurement, compound 4: 5 percentage points above; measured number inside the range.
By their numbers in this assay, from the lowest: compounds 1, 2, 4 and 3 (each within the scatter of the next).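

Going from 2-fluorophenyl to 2,6-difluorophenyl in this assay gives a number 5 percentage points lower from compound 3 to compound 4 (within the scatter). Within the data shown here, this is the first measured pair in which fluoro simply replaces hydrogen, and it shows that filling this second place, on an aromatic carbon ortho to a large group, leaves the growth inhibition indistinguishable from that of the singly fluorinated compound. No measurement is available that would account for this result.

What an amine, a carboxylic acid or a longer chain at this same place would do remains open, since fluoro and trifluoromethyl are the only groups shown on this ring. On these data alone, each of the four numbers also lies within the scatter of the next, so it is still unknown whether any change on this ring can shift the read-out beyond that scatter.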